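Swapping the amide aryl group in a cell-growth series

This account rests on a few compounds, and the source may have more. Where it says the series, first, only, none or still open, it means among the compounds named here.

In a functional assay on HepG2 cells (Homo sapiens) for inhibition, read by MTT assay, with a stated time of 72 h (on this read-out lower numbers stand for stronger inhibition and higher numbers for weaker inhibition), compound 2 `Cn1cc(-c2cnc(N)c(Oc3ccc(C(=O)Nc4ccc(Cl)cc4)cc3)n2)cn1` gives 11900 nM, the lower of the two numbers in hand. Compound 1 `Cc1noc(C)c1-c1cnc(N)c(Oc2ccc(C(=O)Nc3cccc(Cl)n3)cc2)n1` gives 35700 nM in this assay; the two compounds differ in more than one place, so only their values can be set side by side. Compound 3 `Cn1cc(-c2cnc(N)c(Oc3ccc(C(=O)Nc4cccc(Cl)n4)cc3)n2)cn1` has not yet been measured. Its change from compound 2 is 6-chloropyridin-2-yl in place of 4-chlorophenyl on an amide-type nitrogen, so compound 3 carries the same amide aryl group as compound 1 on the shared core of compound 2. Nothing in the measured pair isolates this swap. The expectation rests on compound 1 giving 35700 nM with that group, which leans toward a small step to a higher number, though one that may stay within the scatter; the step of a 1.7-fold higher number from compound 2 to compound 3 (0.23 log units; within the scatter) is the estimate. Compound 3 is expected to give 20000 nM, with a range from 7000 nM to 60000 nM.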

Compound 3, half-maximal inhibitory concentration: 44200 nM
Beside the measured number, compound 3's estimate is 2.2-fold (0.34 log units) below it, within the range that was stated.
By their numbers in this assay, from the lowest: compound 2; then compounds 1 and 3 (each within the scatter of the next).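

In this assay, the change from 4-chlorophenyl to 6-chloropyridin-2-yl on the amide-type nitrogen can now be read alone on the shared core, and it gives a 3.7-fold higher number from compound 2 to compound 3 (0.57 log units; beyond the scatter), so the number at this position does respond to this change of aryl group, though only modestly. The other single change, 1-methyl-1H-pyrazol-4-yl in place of 3,5-dimethyl-1,2-oxazol-4-yl on an aromatic carbon, gives a 1.2-fold higher number from compound 1 to compound 3 (0.09 log units; within the scatter), so with 6-chloropyridin-2-yl on the amide these two groups cannot be told apart. No measurement shown here bears on the reason for the step at the amide-type nitrogen.

The compounds shown leave open how a plain phenyl or a 4-methoxyphenyl group would read on this nitrogen. They also leave open whether the same swap would give a similar step with 3,5-dimethyl-1,2-oxazol-4-yl in place on the aromatic carbon.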